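Exocyclic lactone series: aryl in place of dienyl chain

The compounds below may be only part of what the source reports. "The series", "measured", "known", "first", "only" and "open" are said of these compounds alone.

Measured so far:
Compound 1, `C=C1CC[C@@H]2[C@](C)(CO)[C@H](O)CC[C@@]2(C)[C@@H]1/C=C/C1=C/C(=C/C)OC1=O`: 15.1%
Compound 2, `C=C1CC[C@@H]2[C@](C)(CO)[C@H](O)CC[C@@]2(C)[C@@H]1/C=C/C1=C/C(=C/C=C(/C)CCC=C(C)C)OC1=O`: "not active" (no number reported)

The shared core of compound 1 carries a butenolide whose exocyclic double-bonded chain carbon bears the variable group. In an assay on isolated protein for inhibition of Maltase-glucoamylase (Homo sapiens), tested at 100 uM (a higher number here means more inhibition at the concentration tested (going by the name of the read-out), a lower number less inhibition), compound 1 gives 15.1%. In this assay compound 2 is reported only as "not active" (no number reported), so no single number places it; it stands, as far as the words go, no higher than compound 1 and with no figure to rank it.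

Compound 3, `C=C1CC[C@@H]2[C@](C)(CO)[C@H](O)CC[C@@]2(C)[C@@H]1/C=C/C1=C/C(=C/c2ccc(Cl)cc2)OC1=O`, differs from compound 2 in one place: 4-chlorophenyl in place of 2,6-dimethylhepta-1,5-dien-1-yl on a double-bonded chain carbon bound to a double-bonded ring carbon. Among the measured compounds shown here, no measured pair with this change exists in the set, so the size of the step can only be expected. Given that compound 2 shows "not active" (no number reported), any move is expected to be small or, at most, back toward the level of compound 1.

For compound 3 the expected inhibition in this assay is 18%, with a likely range from 0% to 42%.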

Compound 3, a percentage reported as inhibition, at one concentration (the size of the read-out at that concentration, not a potency): "not active" (no number reported)
Compound 3: no number reported; there is nothing to compare the estimate with.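

In this assay, among the compounds shown here, compound 2 and compound 3 are both reported only as "not active", with no number, so no step between them can be read. The compounds shown leave open how the 2,6-dimethylhepta-1,5-dien-1-yl and 4-chlorophenyl groups rank against each other. No data shown bear on this result.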